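The compounds below may be only part of what the source reports. "The series", "measured", "known", "first", "only" and "open" are said of these compounds alone.

Measured so far in an ADME assay on Huh7.5.1 cells (Homo sapiens) for cytotoxicity, read by ATP content, with a stated time of 48 h; on this read-out higher numbers stand for lower toxicity in this test and lower numbers for higher toxicity in this test:

compound 1, `CCCN(CCC)CCNC(=O)C1CCN(Cc2nc(-c3ccccc3C)oc2C)CC1`: 30500 nM
compound 2, `Cc1oc(-c2c(Cl)cccc2C(F)(F)F)nc1CN1CCC(C(=O)NCCCN2C[C@H](C)C[C@H](C)C2)CC1`: 12000 nM
compound 3, `Cc1cccc(-c2nc(CN3CCC(C(=O)NCCCN4C[C@H](C)C[C@H](C)C4)CC3)c(C)o2)c1`: 16500 nM

Compound 3 stands close to the other two on this read-out: its number differs from that of compound 2 by a 1.4-fold higher number from compound 2 to compound 3 (0.14 log units; within the scatter), and the gap to compound 1 is also within the usual scatter, so no ordering of the three can be claimed.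

Compound 4, `Cc1cc(C)cc(-c2nc(CN3CCC(C(=O)NCCCN4C[C@H](C)C[C@H](C)C4)CC3)c(C)o2)c1`, has not yet been measured. It differs from compound 3 in one place: methyl in place of hydrogen on an aromatic carbon.

Among the compounds with values here, the only measured step that touches the same aromatic ring is the one from compound 2 to compound 3, a 1.4-fold higher number from compound 2 to compound 3 (0.14 log units; within the scatter), where a much larger exchange on that ring left the cytotoxicity read-out within the scatter. Compound 1, with a different substituent on that ring and a different amine, also sits within the scatter of compound 3. Within the data shown here, nothing among the measured compounds suggests that adding a methyl group on this ring should move the number beyond the scatter in either direction.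

Compound 4 is therefore expected to give about 18000 nM in this assay, with a range from 8000 nM to 40000 nM; the expected step from compound 3 is a 1.1-fold higher number from compound 3 to compound 4 (0.04 log units; within the scatter).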

Compound 4, half-maximal cytotoxic concentration: 4050 nM
Estimate against measurement, compound 4: 4.4-fold (0.65 log units) above; measured number below the stated range.
By their numbers in this assay, from the lowest: compound 4; then compounds 2, 3 and 1 (each within the scatter of the next, the first and the last beyond it).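

In this assay, methyl in place of hydrogen on an aromatic carbon, meta to a large group and meta to a methyl group, gave a 4.1-fold lower number from compound 3 to compound 4 (0.61 log units; beyond the scatter), so this one added carbon moved the number beyond the scatter, towards higher toxicity in this test. The much larger exchange on the same ring had not done so: 3-methylphenyl in place of 2-chloro-6-(trifluoromethyl)phenyl gave a 1.4-fold higher number from compound 2 to compound 3 (0.14 log units; within the scatter), whereas 3,5-dimethylphenyl in the same place gave a 3.0-fold lower number from compound 2 to compound 4 (0.47 log units; beyond the scatter), which shows that among these three compounds the size of the exchange on this ring does not track the size of the step. Nothing measured here accounts for the step from the 3-methylphenyl to the 3,5-dimethylphenyl ring.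

Going by these compounds, it remains open whether a chlorine, a methoxy group or an ethyl group on the same aromatic carbon would lower the number as the methyl does, or whether the methyl itself is what counts. On these data alone, it is also open whether the 3,5-dimethylphenyl ring would give a similar number when paired with the amine of compound 1 in place of the dimethylpiperidine-bearing propyl chain.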